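Removing the Amide Hydrogen in a Kinase Inhibitor Series

The source may hold more compounds than are shown below. What is called first, only, known or untested is meant among the compounds shown, and "the series" means these compounds.

Measured so far:
- compound 1, `CCC[C@@H]1C(=O)N(C)c2cnc(Nc3ccc(C(=O)NC4CCN(C)CC4)cc3OC)nc2N1C1CCCC1`: 9.9 nM
- compound 2, `COc1cc(C(=O)NC2CCCCC2)ccc1Nc1ncc2c(n1)N(C1CCCC1)[C@H](C)C(=O)N2C`: 160 nM

Of the compounds shown here, two sharing the same core have been tested in an assay on isolated protein for inhibition of serine/threonine-protein kinase PLK1 (Homo sapiens), read by Z'-LYTE; on this read-out higher numbers stand for weaker inhibition and lower numbers for stronger inhibition. Compound 1 gives 9.9 nM in this assay. Compound 2, which carries a cyclohexylamino group on its amide carbonyl and a shorter chain on the core, gives 160 nM. Of the two numbers, compound 2 stands at the higher end, and its gap to compound 1 is beyond the usual scatter, so compound 2 is the weaker inhibitor of the pair.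

Compound 3, `COc1cc(C(=O)N2CCCCC2)ccc1Nc1ncc2c(n1)N(C1CCCC1)[C@H](C)C(=O)N2C`, has not yet been measured. It differs from compound 2 in one place: piperidin-1-yl in place of cyclohexylamino on a carbonyl carbon. The amide loses its hydrogen and becomes part of a ring containing the nitrogen.

Among the compounds with values here, no measured step of this exact kind exists in the data. The expectation is a small step toward a higher number, most likely within the scatter, so that from compound 2 to compound 3 the change in this assay is estimated as a 1.6-fold higher number from compound 2 to compound 3 (0.19 log units; within the scatter). For compound 3 the estimated value is 250 nM, with a range from 80 nM to 800 nM.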

Compound 3, half-maximal inhibitory concentration: 95 nM
Beside the measured number, compound 3's estimate is 2.6-fold (0.42 log units) above it; the range from low to high includes it.
By their numbers in this assay, from the lowest: compound 1; then compounds 3 and 2 (each within the scatter of the next).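

Measured in this assay, piperidin-1-yl in place of cyclohexylamino on a carbonyl carbon gives a 1.7-fold lower number from compound 2 to compound 3 (0.23 log units; within the scatter), so the two compounds cannot be told apart on this read-out. Within the data shown here, this is the first look at a change confined to this position, and it shows that the amide hydrogen, lost along with the hydrogen-bond donor counted for cyclohexylamino, can go without a change beyond the scatter, at least in this pair. Nothing available here says why the two compounds read alike.

Two things changed together in this step, since the amide lost its hydrogen and its nitrogen moved into the ring, and a methyl group on the amide nitrogen of cyclohexylamino would show the loss of the hydrogen apart from that ring change. The compounds shown also leave open how this carbonyl carbon responds to rings holding a further hetero atom, such as morpholin-4-yl or 4-methylpiperazin-1-yl, and whether the result for this one pair carries over to other groups at this position.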